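From fluoro to chloro on the shared core

A few compounds are considered here, and "the series" means these few. Any claim that something is new, unique, unknown or untested is made for them only; others in the source may bear on it.

Compound 1 `COc1nc(N)c2ncn([C@H]3C[C@H](N=[N+]=[N-])[C@@H](CO)O3)c2n1`: > 100000 nM (a limit)
Compound 2 `[N-]=[N+]=N[C@H]1C[C@H](n2cnc3c(N)nc(F)nc32)O[C@@H]1CO`: 30100 nM
Compound 3 `[N-]=[N+]=N[C@H]1C[C@H](n2cnc3c(N)nc(Cl)nc32)O[C@@H]1CO`: not yet measured

In an ADME assay on CCRF-CEM cells (Homo sapiens) for cytotoxicity, with a stated time of 5 days (on this read-out lower numbers stand for stronger inhibition and higher numbers for weaker inhibition), compound 1 stands at the limit of > 100000 nM. Within the data shown here, compound 2, at 30100 nM, holds the only actual number so far. Compound 3 differs from it as follows: chloro in place of fluoro on an aromatic carbon. Among the measured compounds shown here, one measured step bears on this carbon, an at least 3.3-fold lower number from compound 1 to compound 2 (0.52 log units; beyond the scatter), but it exchanges a different pair of groups and starts from a limit. It therefore shows that this carbon matters without giving a size for the new exchange. The expected change is small, a 1.4-fold lower number from compound 2 to compound 3 (0.14 log units; within the scatter), in this assay. Compound 3 is estimated at 22000 nM, with an expected range of 6000 nM to 80000 nM.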

Compound 3, half-maximal inhibitory concentration: > 100000 nM
Compound 3 ended at the assay's limit; the forecaster's own chance of this, stated with the estimate: 15%; middle value at least 4.5-fold (0.65 log units) away from the limit.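

In this assay, chloro in place of fluoro gives an at least 3.3-fold higher number from compound 2 to compound 3 (0.52 log units; beyond the scatter), so this carbon responds even to an exchange of one halogen atom for another, not only to the loss of methoxy. Compound 1 and compound 3 both end at a limit, so the step from compound 1 to compound 3 cannot be read, and fluoro remains the only one of these three groups on this carbon with an actual number: the limit of > 100000 nM in this assay, at which 2 of the 3 values shown sit.

As far as these compounds go, what an amine or a bromo group on this carbon would give stays open. So does whether any group there could bring the number lower than fluoro does.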